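Swapping Chloro for Fluoro on a Trimethoxy Chalcone

A few compounds are considered here, and "the series" means these few. Any claim that something is new, unique, unknown or untested is made for them only; others in the source may bear on it.

For the measured compounds named here, compound 2 `COc1cc(OC)c(C(=O)/C=C/c2ccc(Cl)cc2)c(OC)c1` is the only compound with a number in a functional assay on HaCaT cells (Homo sapiens), read by fluorescence and BrdU incorporation, with a stated time of 48 h, tested at 10 uM (on this read-out lower numbers stand for a stronger effect and higher numbers for a weaker effect at the one concentration tested), where compound 2 gives 26%. Compound 1 `COc1cc(O)c(C(=O)/C=C/c2ccc(F)cc2)c(OC)c1`, a related chalcone, is reported in this assay as "not active" (no number reported). Compound 3 `COc1cc(OC)c(C(=O)/C=C/c2ccc(F)cc2)c(OC)c1` has not yet been measured. It differs from compound 2 by fluoro in place of chloro on an aromatic carbon. With compound 1 showing no measurable activity in this assay, a weakening step toward higher numbers, beyond the usual scatter, is expected for compound 3, a number 29 percentage points higher from compound 2 to compound 3 (beyond the scatter). Compound 3 is therefore estimated at 55%, within a range from 25% to 95%.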

Compound 3, a percentage reported as activity, at one concentration (the size of the read-out at that concentration, not a potency): 20%
Beside the measured number, compound 3's estimate is 35 percentage points above it, outside the stated range (below it).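

In this assay the change from 4-chlorophenyl to 4-fluorophenyl gives a number 6 percentage points lower from compound 2 to compound 3 (within the scatter) on the shared core, so at this carbon, para to a large group, the two halogens cannot be told apart on this read-out. Compound 1 carries the same fluoro and reads "not active" (no number reported) in this assay, so fluoro alone does not go with that outcome. Nothing measured here gives a reason for this result.

Still open, going by these compounds, is whether an amine or a carboxylic acid at this place would leave the read-out unchanged. The compounds shown also leave open what a hydrogen there would give.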